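Swapping methoxy for nitro in a low-toxicity series

The source may hold more compounds than are shown below. What is called first, only, known or untested is meant among the compounds shown, and "the series" means these compounds.

Three compounds sharing one core were tested in an ADME assay on Huh-7 cells (Homo sapiens) for cytotoxicity; on this read-out higher numbers stand for lower toxicity in this test and lower numbers for higher toxicity in this test. Compound 1 `Cc1ccccc1CNc1nn(-c2ccc(F)cc2F)cc1CNCCN1CCN(C)CC1` gives only the limit > 20000 nM, a boundary of the test rather than a number. Compound 2 `CN1CCN(CCNCc2cn(-c3ccc(F)cc3F)nc2C2CCCCC2)CC1` likewise gives only the limit > 20000 nM. Compound 3 `COc1ccc(-n2cc(CNCCN3CCN(C)CC3)c(-c3ccccc3C)n2)cc1` also stops at the limit > 20000 nM, so its standing is known only as a limit. Among the measured compounds shown here, the single one-point step, a step that the two limits leave unreadable from compound 1 to compound 2, cannot be read since both ends are limits. Compound 4 `Cc1ccccc1-c1nn(-c2ccc([N+](=O)[O-])cc2)cc1CNCCN1CCN(C)CC1` differs from compound 3 by nitro in place of methoxy on an aromatic carbon. For the measured compounds named here, no measured step bears on this change; the expectation rests on the limit of > 20000 nM in this assay, at which 3 of the 3 values shown sit, alone. Compound 4 is therefore expected to remain near the limit, at 20000 nM with a range from 10000 nM to 40000 nM. The step of a number no higher from compound 3 to compound 4 (the limit leaves the size open) is expected to be none beyond the scatter.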

Compound 4, half-maximal cytotoxic concentration: > 20000 nM
Compound 4 ended at the assay's limit; the forecaster's own chance of this, stated with the estimate: 80%; the middle value sits exactly at the limit.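

Compound 3 and compound 4 both stop at a limit, so no step can be read between them. Whether nitro in place of methoxy changes the result in this assay stays open, as does any ranking of the compounds shown.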